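The source may hold more compounds than are shown below. What is called first, only, known or untested is meant among the compounds shown, and "the series" means these compounds.

Working notes on the series

The compounds share one core, seen in compound 1 `CNC(=O)c1cc(C(=O)NC2CCC2)cn(Cc2ccncc2)c1=O`, and are compared in a physicochemical assay for lipophilicity, at pH 7.4; a lower number here means a more polar compound, a higher number a more lipophilic compound. Compound 1 gives 1.7. Compound 2 `CNC(=O)c1cc(C(=O)NC2CC2)cn(Cc2cccc([C@@H](C)O)c2)c1=O` gives 2.2 in this assay, the second highest of the three numbers: compound 1 sits below it by a gap beyond the scatter, and compound 3 `CNC(=O)c1cc(C(=O)NC(C)C)cn(Cc2ccccc2)c1=O`, which gives 3.6 in this assay, sits above it by a larger gap, also beyond the scatter. For the measured compounds named here, no two measured compounds differ in one place only, so no single step can be read directly from the measured numbers.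

Compound 4 `CNC(=O)c1cc(C(=O)NC2CC2)cn(CC2CCCCC2)c1=O` has not yet been measured in this assay. Its difference from compound 2 is cyclohexyl in place of 3-(1-hydroxyethyl)phenyl on a saturated chain carbon bound to an aromatic nitrogen. The group that leaves carries one hydrogen-bond donor, one hydrogen-bond acceptor and a defined stereocentre; the group that enters carries none of these. An upward step in this assay, beyond the scatter, is expected, of about a number 1.60 log units higher from compound 2 to compound 4 (beyond the scatter). The expectation rests on compound 3 giving 3.6 in this assay with no hydrogen-bond donor in the group on the saturated chain carbon bound to an aromatic nitrogen. Compound 4 is therefore estimated at 3.8 in this assay, with a range from 3.2 to 4.4.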

Compound 4, distribution coefficient: 4
Estimate against measurement, compound 4: 0.20 log units below; low and high end bracket the measured number.
By their numbers in this assay, from the lowest: compound 1; then compound 2; then compound 3; then compound 4.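

At the saturated chain carbon bound to an aromatic nitrogen, this assay now has its first comparison that differs in one place only: cyclohexyl in place of 3-(1-hydroxyethyl)phenyl gives a large step, a number 1.80 log units higher from compound 2 to compound 4 (beyond the scatter). For the compounds shown here, none of the earlier compounds formed such a pair, so this is the first change that can be tied to this position alone, with the rest of the structure held constant. The change alters several things at once, as the group that leaves has an aromatic ring, hydrogen-bond donor and acceptor functions and a defined stereocentre, while the group that enters has none of these, and nothing available shows which of them accounts for the step.

The compounds shown leave open how the step divides between the change of ring and the loss of the 1-hydroxyethyl group: no pair separates the two. Also open, going by these compounds, is where an aminomethyl group or a carboxylic acid in this place would fall in this assay, and whether a step of this size would recur with a different amide on the shared core.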